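Shortening the Isothiocyanate Chain on Two Sulfoxide Cores

This account rests on a few compounds, and the source may have more. Where it says the series, first, only, none or still open, it means among the compounds named here.

Compound 1 `CC(C)[S+]([O-])CCCCN=C=S`, compound 2 `[O-][S+](CCCCN=C=S)Cc1ccccc1` and compound 3 `[O-][S+](CCCN=C=S)Cc1ccccc1` were all tested in a functional assay on MCF7 cells (Homo sapiens) for cytotoxicity, read by MTT assay, with a stated time of 72 h; on this read-out higher numbers stand for weaker inhibition and lower numbers for stronger inhibition. Compound 1 gives 8820 nM, compound 2 gives 3300 nM and compound 3 gives 7920 nM. Compound 3 differs from compound 2 by a group of 3 heavy atoms (1 carbon, 1 nitrogen, 1 sulfur; no ring) in place of a group of 4 heavy atoms (2 carbon, 1 nitrogen, 1 sulfur; no ring), on a saturated chain carbon, three bonds along the chain from a sulfur, and this change produced a 2.4-fold higher number from compound 2 to compound 3 (0.38 log units; beyond the scatter). Compound 4 `CC(C)[S+]([O-])CCCN=C=S` has not yet been measured; it differs from compound 1 by a group of 3 heavy atoms (1 carbon, 1 nitrogen, 1 sulfur; no ring) in place of a group of 4 heavy atoms (2 carbon, 1 nitrogen, 1 sulfur; no ring), on a saturated chain carbon, three bonds along the chain from a sulfur, the same change as that between compound 2 and compound 3. The difference between the two cores is not broken down here. Because compound 1 already gives 8820 nM and the same change gave a 2.4-fold higher number from compound 2 to compound 3 (0.38 log units; beyond the scatter), he expects a step of about a 2.2-fold higher number from compound 1 to compound 4 (0.33 log units; beyond the scatter) in this assay. His estimate for compound 4 is therefore 19000 nM, expected to fall between 8000 nM and 45000 nM.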

Compound 4, half-maximal inhibitory concentration: 7930 nM
For compound 4 the middle estimate is 2.4-fold (0.38 log units) above the measured one; measured number below the stated range.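

In this assay, the change that shortens the chain on the core of compound 1 gave a 1.1-fold lower number from compound 1 to compound 4 (0.05 log units; within the scatter). The step seen on the other core therefore did not carry over: the same change on two cores in this assay, a 2.4-fold higher number (0.38 log units; beyond the scatter) from compound 2 to compound 3 and a 1.1-fold lower number (0.05 log units; within the scatter) from compound 1 to compound 4, 2.7-fold (0.43 log units) apart, beyond the scatter of two such steps. This shows that, for these two cores, the effect of the change depends on the core it is made on, but it does not show what in the cores is responsible, and a single pair of steps gives no rule for any further core.

The compounds shown leave open how a longer chain would behave on either core. They also leave open whether an amine or a nitrile in place of the isothiocyanate would keep any of this cytotoxicity.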